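The source may hold more compounds than are shown below. What is called first, only, known or untested is meant among the compounds shown, and "the series" means these compounds.

Working notes on the series.

Three compounds on the shared core have numbers in a functional assay on LOX IMVI cells (Homo sapiens) for antiproliferative activity, read by sulforhodamine B assay, with a stated time of 48 h; on this read-out higher numbers stand for weaker inhibition and lower numbers for stronger inhibition. Compound 1 `COc1cc(-c2nn(-c3ccc(NC(=O)Nc4ccc(Cl)c(C(F)(F)F)c4)cc3)cc2-c2ccncc2)ccc1Cl` gives 1430 nM in this assay. Going by the values given here, compound 2 `COc1cc(-c2nn(-c3ccc(NC(=O)c4ccc(Cl)c(Cl)c4)cc3)cc2-c2ccncc2)ccc1Cl` gives 2760 nM in this assay, and the step of a 1.9-fold higher number from compound 1 to compound 2 (0.29 log units; within the scatter) is the only measured instance of the carbonyl-substituent exchange. Compound 3 `O=C(Nc1ccc(-n2cc(-c3ccncc3)c(-c3ccc(Cl)c(O)c3)n2)cc1)Nc1ccc(Cl)c(C(F)(F)F)c1` carries hydrogen in place of methyl on an oxygen on an aromatic ring relative to compound 1. In this assay compound 3 gives 1440 nM; the step of a 1.0-fold higher number from compound 1 to compound 3 (0.00 log units; within the scatter) shows that exchange as flat. On the numbers shown compound 3 sits with compound 1 and its gap to compound 2 is also within the scatter, so no order among the three can be read.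

Compound 4 `O=C(Nc1ccc(-n2cc(-c3ccncc3)c(-c3ccc(Cl)c(O)c3)n2)cc1)c1ccc(Cl)c(Cl)c1` is the next member and has not yet been measured. It differs from compound 3 by 3,4-dichlorophenyl in place of (4-chloro-3-(trifluoromethyl)phenyl)amino on a carbonyl carbon. Among the compounds with values here, the one measured step that bears on this change is the step from compound 1 to compound 2, where the same exchange on the carbonyl carbon gave a number higher by an amount that stayed within the scatter. The same size of step, in the same direction, is expected here, and it would again stay within the scatter. For compound 4 the estimate in this assay is 2700 nM, with a range from 1200 nM to 6500 nM, meaning an expected step of a 1.9-fold higher number from compound 3 to compound 4 (0.27 log units; within the scatter).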

Compound 4, half-maximal inhibitory concentration: 1450 nM
Estimate against measurement, compound 4: 1.9-fold (0.27 log units) above; measured number inside the range.
By their numbers in this assay, from the lowest: compounds 1, 3, 4 and 2 (each within the scatter of the next).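

The exchange of (4-chloro-3-(trifluoromethyl)phenyl)amino for 3,4-dichlorophenyl on the carbonyl carbon now has a second instance, on a core with hydrogen rather than methyl on the aromatic oxygen, and in this assay it gives a 1.0-fold higher number from compound 3 to compound 4 (0.00 log units; within the scatter). The upward trend suggested by the single earlier instance is therefore not repeated, although the two instances cannot be told apart: the same change on two cores in this assay, a 1.9-fold higher number (0.29 log units; within the scatter) from compound 1 to compound 2 and a 1.0-fold higher number (0.00 log units; within the scatter) from compound 3 to compound 4, 1.9-fold (0.28 log units) apart, within the scatter of two such steps The exchange of methyl for hydrogen on the aromatic oxygen also gains a second instance, a 1.9-fold lower number from compound 2 to compound 4 (0.28 log units; within the scatter), and, set against its first instance, it too shows no dependence on the group at the carbonyl carbon that can be read: the same change on two cores in this assay, a 1.0-fold higher number (0.00 log units; within the scatter) from compound 1 to compound 3 and a 1.9-fold lower number (0.28 log units; within the scatter) from compound 2 to compound 4, 1.9-fold (0.28 log units) apart, within the scatter of two such steps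

With only two groups on the carbonyl carbon and all four numbers within the scatter of one another, the compounds shown do not establish any group at this position as better than the other. From the compounds shown here alone, whether a quite different group on the carbonyl carbon, such as a simple amine or a longer alkyl chain, or a carboxylic acid on the aromatic ring that sits there, would move the number beyond the scatter remains open.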